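The source may report more compounds than this note shows. Statements on the series, on what has been measured and on what is new or still open speak of the compounds shown alone.

Compound 1 `O=C1C2CCCN2C(=O)N1CN1CCN(c2ccccc2)CC1` is the parent of this small set, carrying hydrogen at the position under study. In an assay on isolated protein for binding affinity to Adrenergic receptor alpha-1 (Rattus norvegicus), read by radioligand binding (a lower number here means a stronger inhibitor, a higher number a weaker inhibitor), compound 1 gives 1000 nM, the highest of the two plain numbers shown. Compound 2 `COc1ccccc1N1CCN(CN2C(=O)C3CCCN3C2=O)CC1` gives 500 nM in this assay, and the move is a 2.0-fold lower number from compound 1 to compound 2 (0.30 log units; within the scatter). Compound 3 `O=C1C2CCCN2C(=O)N1CN1CCN(c2cccc(C(F)(F)F)c2)CC1` in this assay gives only a limit, > 1000 nM. The step of a number no lower from compound 1 to compound 3 (the limit leaves the size open) is therefore of unknown size, since (the limit of > 1000 nM in this assay, at which 1 of the 3 values shown sits).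

Compound 4 `O=C1C2CCCN2C(=O)N1CN1CCN(c2ccc([N+](=O)[O-])cc2)CC1` is not yet measured. It differs from compound 1 by nitro in place of hydrogen on an aromatic carbon. Both measured steps bear on it, since each also puts a group on a hydrogen of the same six-membered aromatic ring of carbon only: methoxy moved the number within the scatter, trifluoromethyl left only a limit. Neither step was read as a gain beyond the scatter, and one points toward the weak side.

Compound 4 is therefore expected to show a 1.5-fold higher number from compound 1 to compound 4 (0.18 log units; within the scatter) in this assay, leaning toward the weak side in view of compound 3 at > 1000 nM. The estimate for compound 4 in this assay is 1500 nM, with a range from 500 nM to 5000 nM, and a real chance that only a limit is reported.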

Compound 4, inhibition constant: > 10000 nM
Compound 4: only a limit was reported; the forecaster's own chance of this, stated with the estimate: 40%; at least 6.6-fold (0.82 log units) between middle value and limit.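

Nitro in place of hydrogen, para to a large group, gives an at least 10-fold higher number from compound 1 to compound 4 (1.00 log units; beyond the scatter) in this assay, the only step in this set whose readable size lies beyond the scatter. As far as these compounds go, compound 4 is held only as a limit, > 10000 nM, so the full size of this loss stays open. The set now shows that a change on this aromatic ring can clearly weaken binding, which methoxy in compound 2 did not show, as its step stays within the scatter, and which trifluoromethyl in compound 3 could not show, as its step cannot be read.

The compounds shown do not separate the effect of the nitro group from the effect of its place on the ring, as no other group here stands para to a large group. From the compounds shown here alone, it also remains open whether an amine, a carboxylic acid or a longer chain at that same place would bring a similar loss, or whether the loss is specific to nitro.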